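This account rests on a few compounds, and the source may have more. Where it says the series, first, only, none or still open, it means among the compounds named here.

Compounds measured in an ADME assay on C8166 cells (Homo sapiens) for cytotoxicity, read by MTT assay; a lower number here means that less compound is tolerated, a higher number that more compound is tolerated:
compound 1, `O=C(O)c1cn(Cc2ccccc2)c2ccc(Cc3ccccc3F)c(O)c2c1=O`, gives 156000 nM;
compound 2, `O=C(O)c1cn(Cc2ccccc2F)c2ccc(Cc3ccccc3F)c(O)c2c1=O`, gives 67100 nM;
compound 3, `O=C(O)c1cn(Cc2ccc(F)cc2)c2ccc(Cc3cccc(Cl)c3F)c(O)c2c1=O`, gives 65800 nM.

Compound 1 and compound 2 differ by fluoro in place of hydrogen on an aromatic carbon, and this change made a 2.3-fold lower number from compound 1 to compound 2 (0.37 log units; beyond the scatter). Compound 3 carries a different core from compound 1; the difference between the two cores is not broken down here. Compound 3 stands close to compound 2 in this assay, and the two values lie within the scatter of each other.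

Compound 4, `O=C(O)c1cn(Cc2ccc(F)c(F)c2)c2ccc(Cc3cccc(Cl)c3F)c(O)c2c1=O`, has not yet been measured. It differs from compound 3 by fluoro in place of hydrogen on an aromatic carbon. This is the same kind of change as that from compound 1 to compound 2, but the surroundings differ: in compound 2 the new fluoro sits ortho to a large group, while in compound 4 it sits ortho to a fluoro group and meta to a large group. Going by the values given here, on the single earlier example, a modest lowering is expected, so the estimated step is a 1.6-fold lower number from compound 3 to compound 4 (0.22 log units; within the scatter). Compound 4 is therefore expected to give about 40000 nM, with a likely range from 15000 nM to 90000 nM.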

Compound 4, half-maximal cytotoxic concentration: 71400 nM
The estimate for compound 4 lay 1.8-fold (0.25 log units) below the measured number, and the stated range covers the measured number.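

In this assay, the fluoro in place of hydrogen gave a 1.1-fold higher number from compound 3 to compound 4 (0.04 log units; within the scatter), so the step on the core of compound 3 lies within the scatter, whereas the step on the core of compound 1 lies beyond it. Even so, the two steps cannot be told apart: the same change on two cores in this assay, a 2.3-fold lower number (0.37 log units; beyond the scatter) from compound 1 to compound 2 and a 1.1-fold higher number (0.04 log units; within the scatter) from compound 3 to compound 4, 2.5-fold (0.40 log units) apart, within the scatter of two such steps. This shows no measurable difference in how the change carries from one core to the other, but it does not show that the change acts alike on both, since each core offers a single step and the new fluoro stands in different surroundings in each pair.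

The compounds shown leave open how this assay responds to a methoxy group or an amine on the benzyl ring in place of the fluoro. They also leave open what happens when the benzyl group on the ring nitrogen gives way to a longer alkyl chain, or when the carboxylic acid gives way to an amide.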